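Swapping the aryl group: what three measurements allow

The source may report more compounds than this note shows. Statements on the series, on what has been measured and on what is new or still open speak of the compounds shown alone.

Compound 2 `COc1ccc(-c2cc(NNC(=O)Nc3cc(Cl)nc(Cl)c3)nc3c2c(C)nn3C)cc1` is assessed in an assay on isolated protein for binding affinity to sphingosine 1-phosphate receptor 2 (Homo sapiens), read by surface plasmon resonance (on this read-out lower numbers stand for tighter binding and higher numbers for weaker binding), where compound 2 gives 1020 nM. Compound 1 `COc1ccc(-c2cc(NNC(=O)Nc3cc(Cl)nc(Cl)c3)nc3c2cnn3C)cc1` gives 520 nM, and compound 3 `CCCc1cc(NNC(=O)Nc2cc(Cl)nc(Cl)c2)nc2c1c(C(F)(F)F)nn2C` gives 890 nM. Compound 2 thus carries the highest of the three numbers, yet both its gap to compound 3 and the step of a 2.0-fold higher number from compound 1 to compound 2 (0.29 log units; within the scatter) lie within the scatter, so none of the three can be called the weaker or the tighter binder. Compound 4 `Cc1nn(C)c2nc(NNC(=O)Nc3cc(Cl)nc(Cl)c3)cc(-c3ccc(Cl)s3)c12` differs from compound 2 by 5-chlorothiophen-2-yl in place of 4-methoxyphenyl on an aromatic carbon. Among the compounds with values here, the only measured step, a 2.0-fold higher number from compound 1 to compound 2 (0.29 log units; within the scatter), concerns a different kind of change and does not bear on this aryl swap. With nothing to guide it, no change beyond the scatter is expected for compound 4 in this assay, the estimated step being a 1.0-fold lower number from compound 2 to compound 4 (0.01 log units; within the scatter). Compound 4 is therefore expected to give about 1000 nM, within a wide range from 300 nM to 3500 nM.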

Compound 4, dissociation constant: 1980 nM
Beside the measured number, compound 4's estimate is 2.0-fold (0.30 log units) below it; low and high end bracket the measured number.
By their numbers in this assay, from the lowest: compounds 1, 3, 2 and 4 (each within the scatter of the next, the first and the last beyond it).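

In this assay, the swap gives a 1.9-fold higher number from compound 2 to compound 4 (0.29 log units; within the scatter), so this exchange of aryl groups cannot be told apart from no change. On this aromatic carbon, a five-membered ring carrying sulfur and chlorine and a six-membered carbon ring carrying methoxy therefore give numbers within the scatter of each other. No available evidence speaks to how either group acts here.

As far as these compounds go, it remains open whether an amine, a carboxylic acid or an unsubstituted phenyl on this carbon would shift the number beyond the scatter.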